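A small heteroaryl swap on a weakly active core

A few compounds are considered here, and "the series" means these few. Any claim that something is new, unique, unknown or untested is made for them only; others in the source may bear on it.

The compounds here share a core in which a nitrile-bearing aryl amine is joined to a second aromatic ring that carries a methyl group and a pendant heteroaryl. Compound 1, `CCN(c1ccc(C#N)c(Cl)c1)c1cc(-c2ccoc2)ccc1C`, carries a furan-3-yl at that pendant position. In a functional assay on PC-3 cells (Homo sapiens) for antiproliferative activity, read by CCK-8 assay, with a stated time of 6 days (on this read-out higher numbers stand for weaker inhibition and lower numbers for stronger inhibition), compound 1 gives only a limit, > 30000 nM, and not a number. For comparison, compound 2, `CCN(c1ccc(C#N)c(Cl)c1)c1cc(-c2cnc3ccccc3c2)ccc1C`, with a quinolin-3-yl at the same place, gives 3570 nM in this assay, while compound 3, `N#Cc1ccc(N2CCCc3c(-c4ccncc4)cccc32)cc1C(F)(F)F`, built on a different, cyclised core with a pyridin-4-yl, gives 28700 nM.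

Compound 4, `CCN(c1ccc(C#N)c(Cl)c1)c1cc(-n2ccnc2)ccc1C`, is the not yet measured partner of compound 1. The change is 1H-imidazol-1-yl in place of furan-3-yl on an aromatic carbon. Within the data shown here, both groups are five-membered aromatic rings of the same size, and no measured pair shows what such a swap does on this core. The expected step is a number no higher from compound 1 to compound 4 (the limit leaves the size open), which is to say none beyond the usual scatter. Compound 4 is therefore estimated at 30000 nM, within a range from 10000 nM to 100000 nM, and the assay may well report only a limit again.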

Compound 4, half-maximal inhibitory concentration: > 30000 nM
Compound 4 gave a limit, no number; the forecaster's own chance of this, stated with the estimate: 60%; the middle value sits exactly at the limit.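

Compound 1 and compound 4 both end at a limit of the assay rather than a number, so no step can be read between them: the limit of > 30000 nM in this assay, at which 2 of the 4 values shown sit. The compounds shown leave open whether 1H-imidazol-1-yl and furan-3-yl differ at all in activity on the shared core.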